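Methoxyphenyl Swapped for Nitrophenyl on the Thioether

The source may hold more compounds than are shown below. What is called first, only, known or untested is meant among the compounds shown, and "the series" means these compounds.

Among the three measured compounds, compound 3 `O=[N+]([O-])c1cccc(SCc2ncnc3c2ncn3[C@@H]2O[C@H](CO)[C@@H](O)[C@H]2O)c1` stands lowest in an assay on isolated protein for binding affinity to Equilibrative nucleoside transporter 1 (Homo sapiens) (on this read-out higher numbers stand for weaker inhibition and lower numbers for stronger inhibition), with 4.79 nM. Compound 2 `OC[C@H]1O[C@@H](n2cnc3c(CSc4cccc(Cl)c4)ncnc32)[C@H](O)[C@@H]1O` gives 282 nM, and compound 1 `Cc1cc(C)c(SCc2ncnc3c2ncn3[C@@H]2O[C@H](CO)[C@@H](O)[C@H]2O)c(C)c1` gives 33100 nM. The unmeasured compound 4 `COc1ccc(SCc2ncnc3c2ncn3[C@@H]2O[C@H](CO)[C@@H](O)[C@H]2O)cc1` differs from compound 3 by 4-methoxyphenyl in place of 3-nitrophenyl on a sulfur. For the measured compounds named here, two measured steps bear on this change: a 6900-fold lower number from compound 1 to compound 3 (3.84 log units; beyond the scatter) and a 59-fold lower number from compound 2 to compound 3 (1.77 log units; beyond the scatter), both showing that the 3-nitrophenyl group goes with a far lower number than either other aryl group measured. Compound 4 gives up that group, so compound 4 is expected to show a step of an 84-fold higher number from compound 3 to compound 4 (1.92 log units; beyond the scatter), a large rise. Compound 4 is accordingly estimated at 400 nM, within a range from 60 nM to 3000 nM.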

Compound 4, half-maximal inhibitory concentration: 617 nM
The estimate for compound 4 lay 1.5-fold (0.19 log units) below the measured number, and the stated range covers the measured number.
By their numbers in this assay, from the lowest: compound 3; then compound 2; then compound 4; then compound 1.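

In this assay, 4-methoxyphenyl in place of 3-nitrophenyl on a sulfur gives a 130-fold higher number from compound 3 to compound 4 (2.11 log units; beyond the scatter) and so does not keep the low number of the nitro compound. The same group gives a 2.2-fold higher number from compound 2 to compound 4 (0.34 log units; beyond the scatter) and only a modest step, while it gives a 54-fold lower number from compound 1 to compound 4 (1.73 log units; beyond the scatter) and so remains far lower than the 2,4,6-trimethylphenyl compound. Nothing available explains these differences.

The compounds shown leave open whether 3-methoxyphenyl would read closer to 3-nitrophenyl than 4-methoxyphenyl does in this assay and how an amine or a carboxylic acid on the phenyl ring would read there.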